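The compounds below may be only part of what the source reports. "The series", "measured", "known", "first", "only" and "open" are said of these compounds alone.

Measured in a functional assay on HepG2 cells (Homo sapiens) for antiproliferative activity, read by MTT assay, with a stated time of 48 h; a lower number here means a stronger inhibitor, a higher number a weaker inhibitor:
Compound 1 `COc1cccc(/C=C/C(=O)N2Cc3ccccc3[C@@H](OCc3ccccc3)[C@@H]2CO)c1OC`: 31000 nM
Compound 2 `COc1cc(/C=C/C(=O)N2Cc3ccccc3[C@@H](OCc3ccccc3)[C@@H]2CO)ccc1O`: 79400 nM

Of these two, compound 2 has the higher number. Compound 3 `O=C(/C=C/c1ccc([N+](=O)[O-])cc1)N1Cc2ccccc2[C@@H](OCc2ccccc2)[C@@H]1CO` carries 4-nitrophenyl in place of 4-hydroxy-3-methoxyphenyl, on a double-bonded chain carbon bound to a double-bonded chain carbon: 4-nitrophenyl in place of 4-hydroxy-3-methoxyphenyl on a double-bonded chain carbon bound to a double-bonded chain carbon. For the measured compounds named here, one measured step bears on this, since it changes the group at the same place: a 2.6-fold higher number from compound 1 to compound 2 (0.41 log units; beyond the scatter). It is modest, so a modest step toward a lower number in this assay is expected, though the direction is uncertain. The step expected is a 1.8-fold lower number from compound 2 to compound 3 (0.25 log units; within the scatter). For compound 3 the estimated value is 45000 nM, with an expected range of 15000 nM to 120000 nM.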

Compound 3, half-maximal inhibitory concentration: 5370 nM
Compound 3: middle estimate off by 8.4-fold (0.92 log units), on the high side; measured number outside the range, below it.
By their numbers in this assay, from the lowest: compound 3; then compound 1; then compound 2.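

In this assay, the group on this double-bonded chain carbon can shift the number far more than the earlier pair showed: 4-nitrophenyl gives a 15-fold lower number from compound 2 to compound 3 (1.17 log units; beyond the scatter) and, against 2,3-dimethoxyphenyl, a 5.8-fold lower number from compound 1 to compound 3 (0.76 log units; beyond the scatter) in the same direction. Compound 3 therefore has the lowest number of the three, with both its steps beyond the scatter. Nothing shown here accounts for the size of these steps. On these data alone, it remains open whether the nitro group itself is required, or whether a phenyl ring bearing an amine or a carboxylic acid in its place would give a similar number.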